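A few compounds are considered here, and "the series" means these few. Any claim that something is new, unique, unknown or untested is made for them only; others in the source may bear on it.

Compound 1 `Cc1cccc2sc(NC(=O)COc3ccc(/C=C4\SC(=O)NC4=O)cc3)nc12` was measured in a functional assay on PC-3 cells (Homo sapiens) for inhibition; a lower number here means a stronger inhibitor of growth, a higher number a weaker inhibitor of growth; in this assay compound 1 gives > 100000 nM, which is a limit of the assay rather than a number. Compound 2 `O=C(COc1ccc(/C=C2\SC(=O)NC2=O)cc1)Nc1ccc([N+](=O)[O-])cc1` was measured in the same way, and compound 2 gives > 100000 nM, again a limit. Compound 3 `O=C(COc1ccc(/C=C2\SC(=O)NC2=O)cc1)Nc1cccc([N+](=O)[O-])c1` gives > 100000 nM, also a limit.

Compound 2 therefore stands at the limit, not at a measured number, and the other two values shown stand there too (the limit of > 100000 nM in this assay, at which 3 of the 3 values shown sit). For the measured compounds named here, the one measured step, a step that the two limits leave unreadable from compound 2 to compound 3, cannot be read from these limits. Compound 4 `O=C(COc1ccc(/C=C2\SC(=O)NC2=O)cc1)Nc1ccc(F)cc1` differs from compound 2 by fluoro in place of nitro on an aromatic carbon. Going by the values given here, no measured step bears on an exchange of this kind, so nothing among the measured compounds points in either direction; with all three values at the limit, the most that can be said is that compound 4 is expected to land near the same limit, meaning a step of a number no higher from compound 2 to compound 4 (the limit leaves the size open) that is not readable as a change. Compound 4 is estimated at 100000 nM, within a range of 30000 nM to 300000 nM.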

Compound 4, concentration for 50% growth inhibition: > 100000 nM
Compound 4: only a limit was reported; the forecaster's own chance of this, stated with the estimate: 80%; the middle value lies on the limit itself.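

In this assay compound 4 gives > 100000 nM, a limit and not a number. For the compounds shown here, no step from compound 2 or compound 3 to compound 4 can be read, and every value shown sits at one limit: the limit of > 100000 nM in this assay, at which 4 of the 4 values shown sit. The compounds shown leave open whether any change to the shared core would give a measurable value.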